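Aryl swap at the saturated ring carbon: compound 4

This account rests on a few compounds, and the source may have more. Where it says the series, first, only, none or still open, it means among the compounds named here.

Compound 3 `COc1cc(CC2C(C#N)=C(N)N(c3ccc(S(N)(=O)=O)cc3)C3=C2C(=O)CCC3)ccc1O` gives 25 ug/mL in a functional assay on Ehrlich cells (Mus musculus) for antiproliferative activity, read by trypan blue exclusion, with a stated time of 2 h (a higher number here means a weaker inhibitor, a lower number a stronger inhibitor), the highest of the two numbers shown; the nearest is compound 2 `N#CC1=C(N)N(c2ccc(S(N)(=O)=O)cc2)C2=C(C(=O)CCC2)C1c1ccc(O)cc1` at 3 ug/mL. Compound 1 `N#CC1=C(N)N(c2ccc(S(N)(=O)=O)cc2)C2=C(C(=O)CCC2)C1c1ccccc1` sits at a limit of the assay, > 100 ug/mL, which is a limit and not a number (the limit of > 100 ug/mL in this assay, at which 1 of the 3 values shown sits). Compound 4 `N#CC1=C(N)N(c2ccc(S(N)(=O)=O)cc2)C2=C(C(=O)CCC2)C1c1c(O)ccc2ccccc12` differs from compound 3 by 2-hydroxynaphthalen-1-yl in place of 4-hydroxy-3-methoxybenzyl on a saturated ring carbon.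

Among the measured compounds shown here, three measured steps bear on this change. First, an at least 33-fold lower number from compound 1 to compound 2 (1.52 log units; beyond the scatter): a hydroxy on an aromatic ring attached to the saturated ring carbon. Second, an at least 4.0-fold lower number from compound 1 to compound 3 (0.60 log units; beyond the scatter). Third, and closest in kind, an 8.3-fold higher number from compound 2 to compound 3 (0.92 log units; beyond the scatter), since compound 4 returns to an aryl group that carries a hydroxy and sits on the saturated ring carbon without the intervening methylene, though now with two six-membered aromatic rings, which no measured compound has. A modest lowering step in this assay is therefore expected. For compound 4 the estimate is 6 ug/mL, with a range from 1.5 ug/mL to 40 ug/mL. This expected move corresponds to a 4.2-fold lower number from compound 3 to compound 4 (0.62 log units; beyond the scatter).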

Compound 4, half-maximal inhibitory concentration: > 100 ug/mL
Compound 4: no number, only a limit; the forecaster's own chance of this, stated with the estimate: 10%; middle value at least 16-fold (1.22 log units) from the limit.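

In this assay compound 4 gives only a limit and not a number, the second such reading in this short series: the limit of > 100 ug/mL in this assay, at which 2 of the 4 values shown sit.

A hydroxy on the aromatic group at the saturated ring carbon therefore does not by itself secure activity, as the change to 2-hydroxynaphthalen-1-yl gives an at least 33-fold higher number from compound 2 to compound 4 (1.52 log units; beyond the scatter) and also an at least 4.0-fold higher number from compound 3 to compound 4 (0.60 log units; beyond the scatter). The step from compound 1 to compound 4 cannot be read, as both values are limits.

The compounds shown do not separate the effect of the second six-membered aromatic ring from that of the hydroxy's location within 2-hydroxynaphthalen-1-yl. From the compounds shown here alone, how an amine or a carboxylic acid in place of the hydroxy of the 4-hydroxyphenyl group would read in this assay also stays open.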